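Amino to cyclopropylamino: a cytotoxicity step awaiting its number

The source may report more compounds than this note shows. Statements on the series, on what has been measured and on what is new or still open speak of the compounds shown alone.

Measured so far in a functional assay on A549 cells (Homo sapiens) for cytotoxicity, read by sulforhodamine B assay, with a stated time of 72 h; on this read-out lower numbers stand for stronger inhibition and higher numbers for weaker inhibition:
Compound 1 `Nc1nc(O)c2ncn([C@@H]3C(F)=C(CO)[C@@H](O)[C@H]3O)c2n1`: > 100000 nM
Compound 2 `Nc1nc(N)c2ncn([C@@H]3C(F)=C(CO)[C@@H](O)[C@H]3O)c2n1`: 85400 nM

Compound 1 gives a limit of the assay and not a number, as the limit of > 100000 nM in this assay, at which 1 of the 2 values shown sits, records. For the measured compounds named here, compound 2, at 85400 nM, therefore holds the only actual number. Going by the values given here, the one measured step, with amino in place of hydroxy on an aromatic carbon, is an at least 1.1-fold lower number from compound 1 to compound 2 (0.06 log units; that floor lies within the scatter).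

Compound 3 `Nc1nc(NC2CC2)c2ncn([C@@H]3C(F)=C(CO)[C@@H](O)[C@H]3O)c2n1` carries the next change, amino to cyclopropylamino: cyclopropyl in place of hydrogen on a nitrogen on an aromatic ring. This places cyclopropyl in place of hydrogen on a nitrogen on an aromatic ring. Among the compounds with values here, no measured compound carries a group on that nitrogen, so the only guides are compound 2 at 85400 nM and the small step of an at least 1.1-fold lower number from compound 1 to compound 2 (0.06 log units; that floor lies within the scatter). A modest move to a lower number is therefore expected in this assay, and it may not clear the scatter. The expected change is a 1.7-fold lower number from compound 2 to compound 3 (0.23 log units; within the scatter). For compound 3 the estimate is 50000 nM, with an expected range from 12000 nM to 120000 nM.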

Compound 3, half-maximal inhibitory concentration: > 100000 nM
Compound 3 gave a limit, no number (the forecaster's own chance of this, stated with the estimate: 35%); middle value at least 2.0-fold (0.30 log units) from the limit.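

Compound 3 is the only compound shown with a group on that nitrogen, and in this assay it returns a limit of the assay and not a number. Going by these compounds, the step reads as an at least 1.1-fold higher number from compound 2 to compound 3 (0.06 log units; that floor lies within the scatter), so cyclopropyl in place of hydrogen shows no move to a lower number, although the true size of the step stays unknown. The step between compound 1 and compound 3 cannot be read, and most of the series now sits at a single limit: the limit of > 100000 nM in this assay, at which 2 of the 3 values shown sit.

The compounds shown leave open whether a smaller group on the same nitrogen, such as methyl, or a longer chain such as n-propyl, would give a number in this assay at all. They also leave open how far compound 3 really lies from compound 2, and whether any change at this position can move the series clearly beyond the scatter.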